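Compound 1 Gains a Ring Hydroxy: What to Expect

The source may report more compounds than this note shows. Statements on the series, on what has been measured and on what is new or still open speak of the compounds shown alone.

Compound 1 `Nc1ncnc2c1ncn2[C@H]1C[C@@H](CO)CO1` stands lowest of the three measured compounds in an assay on CHO cells for displacement of a labelled ligand from adenosine receptor A1 (Homo sapiens), tested at 10 uM (on this read-out lower numbers stand for less inhibition and higher numbers for more inhibition at the one concentration tested (going by the name of the read-out)), where compound 1 gives 10%. Its nearest neighbour is compound 3 `COc1ccc(Cl)cc1CNc1ncnc2c1ncn2[C@@H]1OC[C@@](O)(CO)[C@H]1O`, which gives 13%, a gap within the scatter of this kind of measurement. Furthest away is compound 2 `OC[C@]1(O)CO[C@@H](n2cnc3c(NCc4cccc(I)c4)ncnc32)[C@@H]1O`, which gives 35%, a gap beyond the scatter. Within the data shown here, the only step that can be drawn among the measured compounds, a number 22 percentage points lower from compound 2 to compound 3 (beyond the scatter), swaps one aryl group for another on the saturated chain carbon bound to a nitrogen on the aromatic ring; it tells nothing about the five-membered ring itself.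

Compound 4 `Nc1ncnc2c1ncn2[C@@H]1OC[C@H](CO)[C@H]1O`, not yet measured, differs from compound 1 by hydroxy in place of hydrogen on a saturated ring carbon. Among the measured compounds shown here, no measured step concerns this change. Compounds 2 and 3 do carry a hydroxy on their ring, but they also carry a substituted aryl group on the amine, so their values cannot be separated into the effect of the hydroxy alone. With nothing to rest on, the step is expected to stay within the scatter in this assay, with no direction favoured, so that a number 4 percentage points higher from compound 1 to compound 4 (within the scatter) is the estimate. Compound 4 is therefore expected to give about 14%, somewhere between 0% and 35%.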

Compound 4, a percentage reported as inhibition, at one concentration (the size of the read-out at that concentration, not a potency): 6%
Beside the measured number, compound 4's estimate is 8 percentage points above it; measured number inside the range.
By their numbers in this assay, from the lowest: compounds 4, 1 and 3 (each within the scatter of the next); then compound 2.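

In this assay, among these compounds, placing a hydroxy on the saturated ring carbon of the five-membered ring, two ring bonds from the ring oxygen, gives a number 4 percentage points lower from compound 1 to compound 4 (within the scatter) in the only step measured at this position. On the core of compound 1, with no aryl group on the amine, the hydroxy therefore brings no difference beyond the scatter at the one concentration tested. Compounds 2 and 3 carried a ring hydroxy only together with a substituted aryl group on the amine, and they could not show this on its own. Nothing available here offers a reason for this result.

Whether the hydroxy would also leave the number within the scatter with a 3-iodophenyl or a 5-chloro-2-methoxyphenyl group on the amine remains open, as no pair among the compounds shown tests this. The compounds shown also leave open what an amino group or a fluorine atom would give on this saturated ring carbon in place of the hydroxy, and whether any such group would bring a step beyond the scatter.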